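The compounds below may be only part of what the source reports. "The series", "measured", "known", "first", "only" and "open" are said of these compounds alone.

In an ADME assay on MT4 cells (Homo sapiens) for cytotoxicity, read by MTT assay (a lower number here means that less compound is tolerated, a higher number that more compound is tolerated), compound 1 `Cc1cnc(NC(=O)CSc2nncnc2-c2ccccc2Cl)c(Br)c1` gives 144000 nM and lies within the scatter of both other measured compounds, compound 2 `O=C(CSc1nncnc1-c1cccc2ccccc12)Nc1ccc(Cl)cc1Cl` at 254000 nM and compound 3 `CCOC(=O)c1ccc(NC(=O)CSc2nncnc2-c2cccc3ccccc23)c(Cl)c1` at 150000 nM in the same read-out. Compound 4 `COC(=O)c1sccc1NC(=O)CSc1nncnc1-c1ccccc1Cl` differs from compound 1 by 2-(methoxycarbonyl)thiophen-3-yl in place of 3-bromo-5-methylpyridin-2-yl on an amide-type nitrogen and keeps the rest of the structure. For the measured compounds named here, one measured step bears on this change, a 1.7-fold lower number from compound 2 to compound 3 (0.23 log units; within the scatter) where ethoxycarbonyl enters, and it is small. Going by the values given here, no measured step covers the exchange of the whole aromatic group on the amide-type nitrogen. No step beyond the scatter is therefore expected in this assay here. The estimated step is a 1.2-fold lower number from compound 1 to compound 4 (0.08 log units; within the scatter) and nothing larger is expected. Compound 4 is estimated at 120000 nM with an expected range of 45000 nM to 280000 nM in this read-out.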

Compound 4, half-maximal cytotoxic concentration: 105000 nM
Estimate against measurement, compound 4: 1.1-fold (0.06 log units) above, within the range that was stated.
By their numbers in this assay, from the lowest: compounds 4, 1, 3 and 2 (each within the scatter of the next, the first and the last beyond it).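

In this assay, exchanging the whole aromatic group on the amide-type nitrogen gives a 1.4-fold lower number from compound 1 to compound 4 (0.14 log units; within the scatter), so a five-membered aromatic ring with methoxycarbonyl can replace the six-membered aromatic ring of 3-bromo-5-methylpyridin-2-yl at this position without a step beyond the scatter. The earlier step covered only a substituent exchange on an aromatic carbon, not the whole group. Nothing available explains this result. Open, as far as these compounds go, is whether a carboxylic acid in place of methoxycarbonyl, or a saturated alkyl chain in place of the whole aromatic group, would also stay within the scatter.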